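The source may hold more compounds than are shown below. What is called first, only, known or untested is meant among the compounds shown, and "the series" means these compounds.

Measured in a functional assay on MCF7 cells (Homo sapiens) for antiproliferative activity, read by CCK-8 assay, with a stated time of 48 h; on this read-out lower numbers stand for stronger inhibition and higher numbers for weaker inhibition:
- Compound 1 `O=C(/C=C/CNCCOc1ccc(Oc2c(-c3ccc(F)cc3)sc3cc(O)ccc23)cc1)N1CCCC1`: 7610 nM
- Compound 2 `CNC(=O)/C=C/CN1CC(Oc2ccc(Oc3c(-c4ccc(F)cc4)sc4cc(O)ccc34)cc2)C1`: > 25000 nM (a limit)
- Compound 3 `O=C(CCCNCCOc1ccc(Oc2c(-c3ccc(F)cc3)sc3cc(O)ccc23)cc1)N1CCC1`: > 25000 nM (a limit)

Compound 2 has no number, only the limit > 25000 nM, and it sits at the limit of > 25000 nM in this assay, at which 2 of the 3 values shown sit. The step to compound 4 `C/C=C/C(=O)NCCOc1ccc(Oc2c(-c3ccc(F)cc3)sc3cc(O)ccc23)cc1` places 2-(((prop-1-en-1-yl)carbonyl)amino)ethyl in place of 1-(3-(methylcarbamoyl)prop-2-en-1-yl)azetidin-3-yl on an oxygen on an aromatic ring.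

Within the data shown here, two measured steps bear on this. The step that the two limits leave unreadable from compound 2 to compound 3 cannot be read. The step of an at least 3.2-fold higher number from compound 1 to compound 3 (0.51 log units; beyond the scatter) lies beyond the scatter and shows that this series can move at least modestly with a side-chain change. Compound 1, at 7610 nM, shows that a measured number is possible with an open chain on that oxygen.

A modest move toward a lower number is therefore expected, and a further limit would be no surprise. The expected step is an at least 1.3-fold lower number from compound 2 to compound 4 (0.14 log units; that floor lies within the scatter). For compound 4 the estimate is 18000 nM, with an expected range of 6000 nM to 40000 nM.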

Compound 4, half-maximal inhibitory concentration: 21700 nM
Compound 4: the middle estimate sits 1.2-fold (0.08 log units) below what was measured, within the range that was stated.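

In this assay compound 4 gives 21700 nM as a real number, so an open chain with (prop-1-en-1-yl)carbonyl on its nitrogen can still be read in this assay. Against the two limits, the steps read an at least 1.1-fold lower number from compound 2 to compound 4 (0.06 log units; that floor lies within the scatter) and an at least 1.1-fold lower number from compound 3 to compound 4 (0.06 log units; that floor lies within the scatter) and neither floor leaves the scatter. Among these compounds, the change on the amine nitrogen gives the first step between two real numbers, a 2.9-fold higher number from compound 1 to compound 4 (0.46 log units; beyond the scatter) and it leaves the (prop-1-en-1-yl)carbonyl compound on the side of weaker inhibition.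

As far as these compounds go, whether a carboxylic acid or a longer chain on that nitrogen would give a lower number than compound 1 stays open.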